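The source may report more compounds than this note shows. Statements on the series, on what has been measured and on what is new or still open speak of the compounds shown alone.

Measured in a toxicity assay on HepG2 2.2.15 cells (Homo sapiens) for cytotoxicity, read by CellTiter-Glo; on this read-out higher numbers stand for lower toxicity in this test and lower numbers for higher toxicity in this test:
- compound 1 `O=C(Nc1cc(F)c(F)c(F)c1)N1Cc2c(-c3ccc(F)cc3F)cnn2CC1C1CC1` gives 32100 nM
- compound 2 `O=C1OC(c2ccc(F)cc2)CN1c1cnn2c1CN(C(=O)Nc1cc(F)c(F)c(F)c1)C(C1CC1)C2` gives 3560 nM
- compound 3 `CC1CN(C(=O)Nc2cc(F)c(F)c(F)c2)Cc2c(N3CC(C#N)CC3=O)cnn21` gives 115000 nM

Compound 1 holds the middle place of the three numbers, with compound 3 higher and compound 2 lower, both gaps beyond the scatter. The next compound is compound 4 `O=C1CC(C(F)(F)F)CN1c1cnn2c1CN(C(=O)Nc1cc(F)c(F)c(F)c1)C(C1CC1)C2`. It carries 2-oxo-4-(trifluoromethyl)pyrrolidin-1-yl in place of the 2,4-difluorophenyl of compound 1 on an aromatic carbon (2-oxo-4-(trifluoromethyl)pyrrolidin-1-yl in place of 2,4-difluorophenyl on an aromatic carbon).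

Going by the values given here, no measured pair differs in one place only, so the size of this step has no direct precedent. Compound 2 and compound 3 both carry a five-membered non-aromatic ring with a carbonyl at that carbon, yet their values lie on opposite sides of compound 1: compound 2 at 3560 nM and compound 3 at 115000 nM. These two therefore give no clear direction, and no step beyond the scatter is expected in this assay. The expected change is a 1.1-fold lower number from compound 1 to compound 4 (0.03 log units; within the scatter). For compound 4 the estimated value is 30000 nM, with an expected range of 8000 nM to 110000 nM.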

Compound 4, half-maximal cytotoxic concentration: 115000 nM
Beside the measured number, compound 4's estimate is 3.8-fold (0.58 log units) below it; the whole stated range lies below it.
By their numbers in this assay, from the lowest: compound 2; then compound 1; then compounds 3 and 4 (each within the scatter of the next).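

In this assay, the series now has its first one-place change at this aromatic carbon of the five-membered aromatic ring: a 3.6-fold higher number from compound 1 to compound 4 (0.55 log units; beyond the scatter) with 2-oxo-4-(trifluoromethyl)pyrrolidin-1-yl in place of 2,4-difluorophenyl. The position is therefore not silent in this read-out, since replacing a six-membered aromatic ring of carbon only with a five-membered non-aromatic ring with 1 hetero atom moves the number beyond the scatter, towards lower toxicity in this test. Nothing available accounts for this step, and this single pair cannot separate the ring exchange from the trifluoromethyl group.

Going by these compounds, it remains open whether 2-oxopyrrolidin-1-yl without the trifluoromethyl group would read closer to compound 1 or to compound 4. Also open, on these data alone, is how an amine or a carboxylic acid on this aromatic carbon would read in this assay.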